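The source may hold more compounds than are shown below. What is called first, only, known or untested is meant among the compounds shown, and "the series" means these compounds.

Measured so far:
compound 1 `CC(CO)NC(=O)/C=C/c1ccccc1` — 98%
compound 2 `CC(O)CNC(=O)/C=C/c1ccccc1` — 99%

In a toxicity assay on HepG2 cells (Homo sapiens) for cytotoxicity, read by trypan blue exclusion, with a stated time of 24 h, tested at 10 uM (on this read-out lower numbers stand for a stronger effect and higher numbers for a weaker effect at the one concentration tested), compound 1 gives 98% and compound 2 gives 99%. Among the compounds with values here, compound 2 stands highest of the two numbers, but its only neighbour is compound 1, and the step of a number 1 percentage points higher from compound 1 to compound 2 (within the scatter) lies within the scatter, so the two cannot be ordered. Compound 3 `CCC(O)CNC(=O)/C=C/c1ccccc1` differs from compound 2 by methyl in place of hydrogen on a saturated chain carbon, two bonds along the chain from an oxygen on a saturated carbon. No measured step shares this change; the one step shown, a number 1 percentage points higher from compound 1 to compound 2 (within the scatter), rearranges the hydroxypropyl chain without adding atoms and is within the scatter. Both measured values sit near the top of the read-out, leaving little room for a higher number. Compound 3 is therefore expected to give about 97%, between 88% and 102%, a step of a number 2 percentage points lower from compound 2 to compound 3 (within the scatter) that is expected to stay within the scatter.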

Compound 3, a percentage reported as activity, at one concentration (the size of the read-out at that concentration, not a potency): 98%
Compound 3: middle estimate off by 1 percentage points, on the low side; low and high end bracket the measured number.
By their numbers in this assay, from the lowest: compounds 1, 3 and 2 (each within the scatter of the next).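

Within the data shown here, the step of a number 1 percentage points lower from compound 2 to compound 3 (within the scatter) is the first to add a heavy atom: methyl in place of hydrogen on a saturated chain carbon, two bonds along the chain from an oxygen on a saturated carbon. The 2-hydroxybutyl chain also shows no change at the digits printed from compound 1 to compound 3 (within the scatter) against the 1-(hydroxymethyl)ethyl chain, so in this assay this change leaves no readable shift at this position. No measured evidence bears on this result.

Open, on these data alone, is whether a longer chain, an amine or a carboxylic acid at this carbon would move the number beyond the scatter.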